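This account rests on a few compounds, and the source may have more. Where it says the series, first, only, none or still open, it means among the compounds named here.

Working notes on the series. In a physicochemical assay for solubility (a higher number here means a more soluble compound, a lower number a less soluble compound), compound 1 (`CN1CCN(c2cc(C(F)(F)F)ccc2[C@H]2CCOc3cc(S(=O)(=O)Nc4nccs4)ccc32)CC1`) gives 176000 nM and compound 2 (`Cc1ccc(-c2cc(C(F)(F)F)ccc2[C@H]2CCOc3cc(S(=O)(=O)Nc4ncc(F)cn4)ccc32)cn1`) gives 225000 nM. Among the measured compounds shown here, these two numbers lie within the scatter of each other, so compound 1 stands level with the only other measured compound. Compound 3 (`O=S(=O)(Nc1nccs1)c1ccc2c(c1)OCC[C@@H]2c1ccc(C(F)(F)F)cc1-c1ccc(F)cn1`) keeps the core of compound 1 and changes one place, with 5-fluoropyridin-2-yl in place of 4-methylpiperazin-1-yl on an aromatic carbon, ortho to a large group and meta to a trifluoromethyl group: 5-fluoropyridin-2-yl in place of 4-methylpiperazin-1-yl on an aromatic carbon.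

For the measured compounds named here, no measured pair isolates this change, so the size of the step has little direct support. Compound 2 differs from compound 1 in more than one place, and compound 2 at 225000 nM gives no sign of a large move in this assay. A modest fall is expected, only a little beyond the scatter, though a result within the scatter would not be surprising. The expected step is a 1.8-fold lower number from compound 1 to compound 3 (0.25 log units; within the scatter). For compound 3 the estimated value is 100000 nM, with an expected range from 30000 nM to 250000 nM.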

Compound 3, solubility: 7000 nM
Estimate against measurement, compound 3: 14-fold (1.15 log units) above; measured number below the stated range.
By their numbers in this assay, from the lowest: compound 3; then compounds 1 and 2 (each within the scatter of the next).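

At this position, on an aromatic carbon ortho to a large group and meta to a trifluoromethyl group, 5-fluoropyridin-2-yl in place of 4-methylpiperazin-1-yl gives a large fall in this assay (a 25-fold lower number from compound 1 to compound 3 (1.40 log units; beyond the scatter)). Among the compounds shown here, this is the first comparison that differs in one place only, and it shows that this position can carry a step well beyond the scatter, even though both groups have 7 heavy atoms, a six-membered ring and no net charge as counted. No measurement at hand bears on the origin of this step.

This single pair cannot separate the loss of the non-aromatic ring from the entry of the aromatic ring, its nitrogen or its fluorine, and compound 2 differs from compound 1 in more than one place, so it cannot settle the question either. As far as these compounds go, open-chain dimethylamino, morpholin-4-yl or unsubstituted phenyl at the same place would divide the step into smaller parts, and whether its size holds with other groups on the sulfonamide nitrogen also remains open.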